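Swapping the Amide Amine on a Pyrrolidine Carboxamide

The source may hold more compounds than are shown below. What is called first, only, known or untested is meant among the compounds shown, and "the series" means these compounds.

Among the measured compounds shown here, compound 3 `O=C(C1CCN(c2ccc(Cl)c(C(F)(F)F)c2)C1)N1CCCC1` gives 410 nM in an assay on cells for inhibition of Palmitoleoyl-protein carboxylesterase NOTUM variant C330S (Homo sapiens), read by fluorescence, with a stated time of 40 min; on this read-out lower numbers stand for stronger inhibition and higher numbers for weaker inhibition; that is the second highest of the three numbers known so far. Compound 2 `O=C(Nc1ccccc1)C1CCN(c2ccc(Cl)c(C(F)(F)F)c2)C1` gives 1000 nM, and compound 1 `Cc1cc(C(=O)O)c(C)n1-c1cccc(C(C)C)c1F` gives 150 nM. Compound 4 `CN1CCN(C(=O)C2CCN(c3ccc(Cl)c(C(F)(F)F)c3)C2)CC1=O` differs from compound 3 by 4-methyl-3-oxopiperazin-1-yl in place of pyrrolidin-1-yl on a carbonyl carbon. For the measured compounds named here, the only measured step at a carbonyl carbon, a 2.4-fold lower number from compound 2 to compound 3 (0.39 log units; beyond the scatter), shows that exchanging the group on the carbonyl can move the number modestly. That step alone bears on the new change, so its direction cannot be foreseen; a step of modest size either way, or none beyond the scatter, is expected, a 1.2-fold higher number from compound 3 to compound 4 (0.09 log units; within the scatter). Compound 4 is therefore estimated at 500 nM, within 200 nM to 1500 nM.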

Compound 4, half-maximal inhibitory concentration: 3100 nM
Estimate against measurement, compound 4: 6.2-fold (0.79 log units) below, and the stated range ends below it.
By their numbers in this assay, from the lowest: compound 1; then compound 3; then compound 2; then compound 4.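

In this assay, this position proves more sensitive than the earlier step suggested: the new group gives a 7.6-fold higher number from compound 3 to compound 4 (0.88 log units; beyond the scatter), the largest step among these compounds. It also compares poorly with anilino, giving a 3.1-fold higher number from compound 2 to compound 4 (0.49 log units; beyond the scatter), so neither amide in the earlier pair is matched by 4-methyl-3-oxopiperazin-1-yl. No supporting measurement explains the rise. On these data alone, the ring size, the ring carbonyl and the methyl all change at once, so their separate contributions remain open. Piperidin-1-yl or an unsubstituted piperazin-1-yl on the same carbonyl carbon would begin to separate them.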